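One Inverted Stereocentre and What Follows for Compound 3

The source may hold more compounds than are shown below. What is called first, only, known or untested is meant among the compounds shown, and "the series" means these compounds.

Compound 1 (`C[C@H]1CN(c2cc(-c3cc(C(F)(F)F)c4c(N)ncnn34)ccc2C#N)C(=O)C(C)(C)O1`) gives 29% in an ADME assay on microsomes from liver (Rattus norvegicus) (a higher number here means that more of the compound is left, a lower number that less of the compound is left), and compound 2 (`C[C@@H]1CN(c2cc(-c3cc(Cl)c4c(N)ncnn34)ccc2C#N)C(=O)C(C)(C)O1`) gives 5% in the same test. Compound 2 is therefore the lower of the two, and the gap lies beyond the scatter. Compound 3 (`C[C@H]1CN(c2cc(-c3cc(Cl)c4c(N)ncnn34)ccc2C#N)C(=O)C(C)(C)O1`) has not yet been measured. The difference from compound 2 is this: the two compounds have the same atoms and bonds and differ only in configuration as drawn: 1 of 1 stereo elements differ; a stereocentre at a saturated ring carbon is drawn R in compound 2 and S in compound 3 (a stereocentre at a saturated ring carbon is drawn R in compound 2 and S in compound 3). Among the measured compounds shown here, no measured pair shows what such a change does in this assay and the expectation stays loose. With compound 2 at 5% there is little room to fall, so a modest rise is expected. The expected a number 6 percentage points higher from compound 2 to compound 3 (within the scatter) is upward and stays within the scatter. In this assay the estimate for compound 3 is 11% with 3% to 30% as the expected range.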

Compound 3, percent of the compound remaining: 0%
The estimate for compound 3 lay 11 percentage points above the measured number, and the stated range ends above it.
By their numbers in this assay, from the lowest: compounds 3 and 2 (each within the scatter of the next); then compound 1.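

In this assay, inverting the stereocentre at the saturated ring carbon gives a number 5 percentage points lower from compound 2 to compound 3 (within the scatter), so this change has no effect that can be told from the scatter, although both compounds lie so close to the bottom of the read-out that a further loss could hardly show. This step bears on the stereocentre alone because of one feature of the pair: the fact that compounds 2 and 3 differ only in the configuration as drawn. Among the compounds shown here, with the configuration as drawn held constant, chloro in place of trifluoromethyl on an aromatic carbon gives a number 29 percentage points lower from compound 1 to compound 3 (beyond the scatter), the first single-place reading of that change, and it lies beyond the scatter.

The compounds shown leave open what the same inversion does when trifluoromethyl is present, where more of the compound remains and a shift would be easier to see. They also leave open how a methyl or methoxy group on that aromatic carbon would compare.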